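The source may report more compounds than this note shows. Statements on the series, on what has been measured and on what is new or still open speak of the compounds shown alone.

In a functional assay on HOS cells (Homo sapiens) for inhibition, with a stated time of 72 h (a lower number here means a stronger inhibitor, a higher number a weaker inhibitor), three close relatives have been measured. Compound 1 `NC1CCC(Nc2nc(NCc3ccc(-c4ccco4)cc3)c3ncn(C4CCCC4)c3n2)CC1` gives 102 nM, compound 2 `NC1CCC(Nc2nc(NCc3ccc(-c4ccsc4)cc3)c3ncn(C4CCCC4)c3n2)CC1` gives 120 nM and compound 3 `NC1CCC(Nc2nc(NCc3ccc(-n4cccn4)cc3)c3ncn(C4CCCC4)c3n2)CC1` gives 103 nM. Compound 1 therefore stands level with the other two, with every gap inside the usual scatter.

Compound 4 `NC1CCC(Nc2nc(NCc3ccc(-c4cccs4)nc3)c3ncn(C4CCCC4)c3n2)CC1` has not been measured yet. It keeps the shared core but alters the group on a saturated chain carbon bound to a nitrogen on an aromatic ring: 6-(thiophen-2-yl)pyridin-3-yl in place of 4-(furan-2-yl)phenyl on a saturated chain carbon bound to a nitrogen on an aromatic ring. This is 6-(thiophen-2-yl)pyridin-3-yl in place of 4-(furan-2-yl)phenyl, so two things change at once: the five-membered aromatic ring, and the six-membered aromatic ring, which now holds a hetero atom.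

Only the first change has a measured parallel. Thiophen-3-yl in place of furan-2-yl gives a 1.2-fold higher number from compound 1 to compound 2 (0.07 log units; within the scatter), and 1H-pyrazol-1-yl in place of furan-2-yl gives a 1.0-fold higher number from compound 1 to compound 3 (0.00 log units; within the scatter). Both steps are within the scatter, so a swap of this ring alone is expected to do little. Among the compounds with values here, no measured compound alters the six-membered ring, and that part stays open, which calls for a wide range.

The step expected in this assay is a 1.3-fold higher number from compound 1 to compound 4 (0.11 log units; within the scatter), which is no clear shift in either direction. The estimated value for compound 4 is 130 nM, with an expected range from 55 nM to 310 nM.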

Compound 4, half-maximal inhibitory concentration: 32 nM
Compound 4: middle estimate off by 4.1-fold (0.61 log units), on the high side; measured number below the stated range.
By their numbers in this assay, from the lowest: compound 4; then compounds 1, 3 and 2 (each within the scatter of the next).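

Among compounds 1, 2 and 3, changing only the five-membered aromatic ring left every gap within the scatter, so this position looked insensitive in this assay. The new group shows that it is not: compound 4 is the strongest inhibitor of the four, with clear steps from each of the others (a 3.2-fold lower number from compound 1 to compound 4 (0.50 log units; beyond the scatter); a 3.2-fold lower number from compound 3 to compound 4 (0.51 log units; beyond the scatter); a 3.8-fold lower number from compound 2 to compound 4 (0.57 log units; beyond the scatter)). The size of these three steps is much the same, and the step that differs from all earlier ones is the one that also places a hetero atom in the six-membered aromatic ring, although the thiophen-2-yl ring enters at the same time and the two changes cannot be told apart; the data at hand offer no explanation for the gain.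

Two groups would separate these changes: 4-(thiophen-2-yl)phenyl, which keeps the carbon-only six-membered ring, and 6-(furan-2-yl)pyridin-3-yl, which keeps the furan. On these data alone, it also remains open whether a small amine or a carboxylic acid in place of the thiophen-2-yl ring would keep the lower number seen with the pyridine.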